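Bromo for fluoro on a pyrazine hydrazone: cytotoxicity outlook

The source may report more compounds than this note shows. Statements on the series, on what has been measured and on what is new or still open speak of the compounds shown alone.

Measured compounds:
compound 1, `O=C(N/N=C/c1ccccc1F)c1cnccn1`, 81%
compound 2, `O=C(N/N=C/c1cccc(F)c1)c1cnccn1`, 40%
compound 3, `O=C(N/N=C/c1ccccc1Br)c1cnccn1`, 91%

Three compounds were examined in an ADME assay on J774 cells (Mus musculus) for cytotoxicity, read by MTT assay, with a stated time of 48 h, tested at 150 ug/mL; a higher number here means a weaker effect of the compound at the concentration tested, a lower number a stronger effect. Compound 1 gives 81% in this assay, and compound 3 gives 91%. Compound 3 differs from compound 1 by bromo in place of fluoro on an aromatic carbon, and the step of a number 10 percentage points higher from compound 1 to compound 3 (within the scatter) is small. Compound 2, with 40%, stands lowest of the three; its distance from compound 1 and from compound 3 is beyond the scatter. Compound 2 and compound 1 share the same atoms joined differently, and the difference between the two cores is not broken down here.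

Compound 4, `O=C(N/N=C/c1cccc(Br)c1)c1cnccn1`, has not yet been measured. It differs from compound 2 by bromo in place of fluoro on an aromatic carbon. This is the same kind of change as that from compound 1 to compound 3, but the place is not the same: in one pair the change sits ortho to a large group, in the other meta to a large group. Because the step of a number 10 percentage points higher from compound 1 to compound 3 (within the scatter) stayed within the scatter, a similarly small step is expected here: a number 8 percentage points higher from compound 2 to compound 4 (within the scatter) is the estimated step from compound 2 to compound 4. Compound 4 is accordingly expected to give 48% in this assay, with a range of 30% to 70%. The estimate rests on a single precedent and on the low value of compound 2.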

Compound 4, a percentage reported as activity, at one concentration (the size of the read-out at that concentration, not a potency): 93%
Compound 4: middle estimate off by 45 percentage points, on the low side; measured number above the stated range.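

In this assay, bromo in place of fluoro on an aromatic carbon, meta to a large group, gives a number 53 percentage points higher from compound 2 to compound 4 (beyond the scatter), which is a large step. Set beside the earlier pair, the same change does not carry over from one core to the other with one size: the same change on two cores in this assay, a number 10 percentage points higher (within the scatter) from compound 1 to compound 3 and a number 53 percentage points higher (beyond the scatter) from compound 2 to compound 4, 43 percentage points apart, beyond the scatter of two such steps This shows that, in these four compounds, a step read on one core cannot be taken as the size of the step on the other, but it does not show why the two steps differ, and two pairs give no rule for any further core in the series.

The compounds shown leave open whether compound 2, which gives 40%, is a lone low value or one of several among compounds with a group in that place, as might be seen with a chloro group, a methoxy group or a nitrile. They also leave open how the numbers in this assay would run with an amine or a carboxylic acid on the same aromatic ring, and whether the bromo for fluoro step would then keep either of its two sizes.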